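The compounds below may be only part of what the source reports. "The series", "measured", "known", "first", "only" and "open" are said of these compounds alone.

Working notes on the series in an ADME assay on BJ cells (Homo sapiens) for cytotoxicity, with a stated time of 72 h; on this read-out lower numbers stand for an effect already at smaller amounts and higher numbers for an effect only at larger amounts of compound. Compound 1 (`O=C(Nc1ccc(F)c(-c2nc3ccccc3s2)c1)c1cc([N+](=O)[O-])ccc1Cl`) reads > 25000 nM, which is a limit. Compound 2 (`O=C(Nc1ccc(O)c(-c2nc3ccccc3s2)c1)c1cc([N+](=O)[O-])ccc1Cl`) reads > 25000 nM, also a limit. Compound 3 (`O=C(Nc1ccc(Cl)c(-c2nc3ccccc3s2)c1)c1cc([N+](=O)[O-])ccc1Cl`) reads > 25000 nM, again a limit, so it has no number of its own. The whole measured picture is the limit of > 25000 nM in this assay, at which 3 of the 3 values shown sit.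

Compound 4 (`COc1ccc(NC(=O)c2cc([N+](=O)[O-])ccc2Cl)cc1-c1nc2ccccc2s1`) differs from compound 3 by methoxy in place of chloro on an aromatic carbon, ortho to a 1,3-benzothiazol-2-yl group. Three measured exchanges on that carbon bear on this change: a step that the two limits leave unreadable from compound 1 to compound 2, a step that the two limits leave unreadable from compound 1 to compound 3 and a step that the two limits leave unreadable from compound 2 to compound 3. None of them has a readable size, so no step beyond the scatter is expected, and no direction can be assigned.

Compound 4 is expected to be reported as a limit as well. As a number, the estimate for compound 4 is 30000 nM, with an expected range of 12000 nM to 60000 nM. The estimated change is a step that the limit leaves unreadable from compound 3 to compound 4.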

Compound 4, half-maximal effective concentration: > 25000 nM
Compound 4: a limit, no number; the forecaster's own chance of this, stated with the estimate: 85%; the middle value does not contradict the limit.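

The steps from compound 1, compound 2 and compound 3 to compound 4 cannot be read, since the series stays at a single limit: the limit of > 25000 nM in this assay, at which 4 of the 4 values shown sit.

The compounds shown leave open where any of their actual values lie in this assay, and whether the exchanges on that aromatic carbon change the read-out at all.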